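One Stereocentre Inverted, Same Atoms and Bonds

The compounds below may be only part of what the source reports. "The series", "measured", "known", "first", "only" and "open" are said of these compounds alone.

For the measured compounds named here, in an ADME assay on MT4 cells (Homo sapiens) for cytotoxicity, read by MTT assay, with a stated time of 5 days (a higher number here means that more compound is tolerated, a lower number that less compound is tolerated), compound 2 (`N#Cc1ccc(Nc2nccc([C@H](O)c3ccc(-c4ccc(C#N)cc4)cc3C(F)(F)F)n2)cc1`) gives 24100 nM and holds the higher of the two numbers measured so far. In this assay compound 1 (`COc1cc(-c2ccc(C#N)cc2)ccc1[C@H](O)c1ccnc(Nc2ccc(C#N)cc2)n1`) stands lower at 9070 nM and that gap lies beyond the usual scatter.

The next compound to be measured is compound 3 (`N#Cc1ccc(Nc2nccc([C@@H](O)c3ccc(-c4ccc(C#N)cc4)cc3C(F)(F)F)n2)cc1`). Set against compound 2, it shows this difference: the two compounds have the same atoms and bonds and differ only in configuration as drawn: 1 of 1 stereo elements differ; a stereocentre at a saturated chain carbon is drawn R in compound 2 and S in compound 3 (the two compounds have the same atoms and bonds, and a stereocentre at a saturated chain carbon is drawn R in compound 2 and S in compound 3). Going by the values given here, no measured pair shows what such an inversion does here, so the expectation starts from compound 2 at 24100 nM and stays close to it. In this assay no step beyond the scatter is expected, with at most a slight drift toward a lower number. The estimated change is a 1.2-fold lower number from compound 2 to compound 3 (0.08 log units; within the scatter) and it is expected to remain within the scatter. Compound 3 is estimated at 20000 nM with an expected range from 9000 nM to 45000 nM before any measurement.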

Compound 3, half-maximal cytotoxic concentration: 9780 nM
Compound 3: the middle estimate sits 2.0-fold (0.31 log units) above what was measured; low and high end bracket the measured number.
By their numbers in this assay, from the lowest: compounds 1 and 3 (each within the scatter of the next); then compound 2.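

In this assay, for the compounds shown here, the inversion of the stereocentre at a saturated chain carbon gives a 2.5-fold lower number from compound 2 to compound 3 (0.39 log units; beyond the scatter) and so moves the number beyond the scatter, which is the first sign that the configuration drawn at this carbon matters for how much compound the cells tolerate. The step can be tied to that one carbon and to nothing else in the structure, because no atom or bond changes between the two compounds: the fact that compounds 2 and 3 differ only in the configuration as drawn. The other new comparison, trifluoromethyl in place of methoxy on an aromatic carbon, gives a 1.1-fold higher number from compound 1 to compound 3 (0.03 log units; within the scatter) and stays within the scatter, so among the compounds shown the inversion is the only single change with a step that can be told from repeat variation.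

From the compounds shown here alone, whether inverting the same stereocentre gives a step of similar size when methoxy rather than trifluoromethyl sits on the aromatic carbon remains open. Going by these compounds, it is also open how the two configurations would compare with a different group in that place, such as an amine or a carboxylic acid.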